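A few compounds are considered here, and "the series" means these few. Any claim that something is new, unique, unknown or untested is made for them only; others in the source may bear on it.

Measured compounds in a functional assay on U-251 cells (Homo sapiens) for inhibition, read by colony formation, with stated times of 48 h and 2 weeks, tested at 10 uM; on this read-out lower numbers stand for less inhibition and higher numbers for more inhibition at the one concentration tested (going by the name of the read-out):

compound 1, `COc1ccc2[nH]cc(/C=C/C(=O)c3ccncc3)c2c1`: 2%
compound 2, `COc1ccc2[nH]cc(/C=C/C(=O)c3cccnc3)c2c1`: 99%

Among the compounds with values here, compound 2 stands highest of the two numbers; its nearest neighbour is compound 1, and the gap between them is the one measured step, a number 97 percentage points higher from compound 1 to compound 2 (beyond the scatter), a change of the six-membered aromatic ring on the carbonyl carbon.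

Compound 3, `COc1ccc2[nH]cc(/C=C/C(=O)c3cnccn3)c2c1`, is not yet measured. It differs from compound 2 in the same position: pyrazin-2-yl in place of pyridin-3-yl on a carbonyl carbon.

Within the data shown here, no measured step covers this exact exchange. Among the measured compounds shown here, the only step, a number 97 percentage points higher from compound 1 to compound 2 (beyond the scatter), shows that the ring on the carbonyl carbon can swing the read-out across nearly its whole range, so a large step in either direction is possible here, and a step beyond the scatter is more likely than none. With the pyrazin-2-yl ring carrying two hetero atoms where compound 2 carries one, the estimate for compound 3 is held toward the middle of the range: 55%, between 10% and 95%, which means an expected step of a number 44 percentage points lower from compound 2 to compound 3 (beyond the scatter).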

Compound 3, a percentage reported as inhibition, at one concentration (the size of the read-out at that concentration, not a potency): 96%
Estimate against measurement, compound 3: 41 percentage points below; measured number above the stated range.
By their numbers in this assay, from the lowest: compound 1; then compounds 3 and 2 (each within the scatter of the next).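

In this assay, the exchange of pyridin-3-yl for pyrazin-2-yl on the carbonyl carbon gives a number 3 percentage points lower from compound 2 to compound 3 (within the scatter), so the second hetero atom in the ring leaves the read-out unchanged within the scatter. The pyrazin-2-yl ring also gives a number 94 percentage points higher from compound 1 to compound 3 (beyond the scatter), so a large step away from pyridin-4-yl is no longer seen with pyridin-3-yl alone. Among these three compounds, only compound 1 gives a low number, and the number stays level when pyrazin-2-yl takes the place of pyridin-3-yl on the carbonyl carbon.

With one concentration tested, this read-out cannot separate compound 2 from compound 3, and a phenyl ring on the carbonyl carbon would show whether a ring nitrogen is needed at all. No measurement on hand explains why pyridin-4-yl differs from the other two rings.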